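Hydroxy in place of 2-aminophenyl: working notes

The source may report more compounds than this note shows. Statements on the series, on what has been measured and on what is new or still open speak of the compounds shown alone.

Among the measured compounds shown here, in a functional assay on A-431 cells (Homo sapiens) for cytotoxicity, read by resazurin assay (on this read-out higher numbers stand for weaker inhibition and lower numbers for stronger inhibition), compound 2 (`C#Cc1cccc(Nc2ncnc3ccc(S(=O)(=O)n4ccc(/C=C/C(=O)Nc5ccccc5N)c4)cc23)c1`) gives 3700 nM, the only actual number so far. Compound 1 (`C#Cc1cccc(Nc2ncnc3ccc(NC(=O)c4ccc(C(=O)Nc5ccccc5N)nc4)cc23)c1`) reads > 16000 nM, which is a limit of this assay and not a number. Compound 3 (`C#Cc1cccc(Nc2ncnc3ccc(S(=O)(=O)n4ccc(/C=C/C(=O)NO)c4)cc23)c1`) carries hydroxy in place of 2-aminophenyl on an amide-type nitrogen. For the measured compounds named here, no measured step covers this change, so the expectation is a judgement from the structures alone. The expected step, a 7.4-fold lower number from compound 2 to compound 3 (0.87 log units; beyond the scatter), runs towards stronger inhibition and beyond the scatter. Compound 3 is estimated at 500 nM, with an expected range of 100 nM to 2500 nM.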

Compound 3, half-maximal inhibitory concentration: 260 nM
Estimate against measurement, compound 3: 1.9-fold (0.28 log units) above; measured number inside the range.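

In this assay hydroxy in place of 2-aminophenyl on an amide-type nitrogen gives a 14-fold lower number from compound 2 to compound 3 (1.15 log units; beyond the scatter). Among the compounds shown here, this is the first step read, and it shows that the aromatic ring on this nitrogen can be lost with a large move towards stronger inhibition. No measurement shown accounts for the size of this step.

On these data alone, for compound 1, > 16000 nM is a limit of the assay, so whether the same change would carry over to its side chain stays open. Also open, as far as these compounds go, is how an amine or a methoxy group on the same nitrogen would read.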